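One Phenyl Less on the Ester Chain

The source may hold more compounds than are shown below. What is called first, only, known or untested is meant among the compounds shown, and "the series" means these compounds.

Of the compounds shown here, three have been measured in an assay on ileum for inhibition of Voltage-dependent L-type calcium channel subunit alpha-1C (Cavia porcellus); on this read-out higher numbers stand for weaker inhibition and lower numbers for stronger inhibition. Compound 1 `CCOC(=O)C1=C(C)NC(C)=C(C(=O)OC)C1c1[nH]c(CC)nc1Cl` gives 2.02 nM, compound 3 `CCOC(=O)C1=C(C)NC(C)=C(C(=O)OCc2ccccc2)C1c1[nH]c(CC)nc1Cl` gives 2.66 nM, and compound 2 `CCc1nc(C2C(C(=O)OCCc3ccccc3)=C(C)NC(C)=C2C(=O)OCCc2ccccc2)c(Cl)[nH]1` gives 0.0437 nM. Compound 3 and compound 1 differ in one place only: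

hydrogen in place of phenyl on a saturated chain carbon bound to an oxygen next to a carbonyl group

That change gave a 1.3-fold lower number from compound 3 to compound 1 (0.12 log units; within the scatter). Compound 2 stands apart from both: its number lies far lower than those of compound 1 and compound 3, by margins beyond the scatter. The difference between the core of compound 2 and the core of compound 3 is not broken down here.

Compound 4 `CCOC(=O)C1=C(C)NC(C)=C(C(=O)OCCc2ccccc2)C1c1nc(CC)[nH]c1Cl` has not been measured yet. It differs from compound 2 as follows:

hydrogen in place of phenyl on a saturated chain carbon, two bonds along the chain from an oxygen next to a carbonyl group

Among the compounds with values here, this is the same kind of change as the one from compound 3 to compound 1, not the same: there the phenyl left a saturated chain carbon bound to an oxygen next to a carbonyl group, here it leaves a saturated chain carbon two bonds along the chain from an oxygen next to a carbonyl group.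

Compound 4 is expected to give about 0.3 nM, within 0.07 nM to 1.5 nM. The expected step from compound 2 to compound 4 is a 6.9-fold higher number from compound 2 to compound 4 (0.84 log units; beyond the scatter). This rests on compound 2 at 0.0437 nM sitting far below compound 1 at 2.02 nM, even though the one measured removal of a phenyl gave only a 1.3-fold lower number from compound 3 to compound 1 (0.12 log units; within the scatter).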

Compound 4, half-maximal inhibitory concentration: 0.0457 nM
Estimate against measurement, compound 4: 6.6-fold (0.82 log units) above; the whole stated range lies above it.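

Taking the phenyl off one of the two ester chains of compound 2 made no real difference in this assay: the result was a 1.0-fold higher number from compound 2 to compound 4 (0.02 log units; within the scatter). Set beside the earlier removal of a phenyl, on a different core, this step tells the same story: the same change on two cores in this assay, a 1.3-fold lower number (0.12 log units; within the scatter) from compound 3 to compound 1 and a 1.0-fold higher number (0.02 log units; within the scatter) from compound 2 to compound 4, 1.4-fold (0.14 log units) apart, within the scatter of two such steps

So in these two pairs, replacing a phenyl with hydrogen carries from one core to the other without a measurable effect, but the phenyl leaves a different chain carbon in each pair, and two pairs show agreement between these compounds rather than a rule for the whole series.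

The compounds shown leave open whether an ethyl ester on both sides of the core of compound 4 would give a similar number, since the phenyl of its remaining phenethyloxy chain stays in place. They also leave open how an amine or a carboxylic acid at the end of that chain, or a longer chain, would compare with phenethyloxy and ethoxy.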